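Guanine-core B-cell agonists: swapping a dichlorobenzyl arm

The compounds below may be only part of what the source reports. "The series", "measured", "known", "first", "only" and "open" are said of these compounds alone.

Measured compounds:
compound 1 `C=CCn1c(=O)n(C2OC(CO[Si](c3ccccc3)(c3ccccc3)C(C)(C)C)[C@@H](O)[C@H]2O)c2nc(N)nc(O)c21` 33%
compound 2 `C=CCn1c(=S)n(COCCO)c2nc(N)nc(O)c21` 9%
compound 3 `Nc1nc(O)c2c(n1)n(C1OC(CO)[C@@H](O)[C@H]1O)c(=O)n2Cc1ccc(Cl)c(Cl)c1` 55%

In a functional assay on the whole organism (B cells) with Mus musculus as the target (on this read-out lower numbers stand for smaller maximal responses and higher numbers for larger maximal responses), compound 3 gives 55%, the highest of the three numbers. Its nearest neighbour is compound 1 at 33%, a gap beyond the scatter, and the furthest is compound 2 at 9%, also beyond the scatter. No single-point steps exist among these three, so the account turns to the unmeasured compound 4 `[N-]=[N+]=NCC(O)Cn1c(=O)n(C2OC(CO)[C@@H](O)[C@H]2O)c2nc(N)nc(O)c21`, which differs from compound 3 in one place: 2-azido-1-hydroxyethyl in place of 3,4-dichlorophenyl on a saturated chain carbon bound to an aromatic nitrogen.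

Going by the values given here, the series offers no direct precedent for this exchange. The two compounds lacking the 3,4-dichlorobenzyl arm, compound 1 and compound 2, both sit well below compound 3, which suggests that losing it may cost maximal response, though neither is a one-place comparison. A downward step in this assay is therefore expected, a number 25 percentage points lower from compound 3 to compound 4 (beyond the scatter), beyond the scatter but not to the floor. Compound 4 is estimated at 30%, with a range from 10% to 52%.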

Compound 4, largest response reached (reported as maximal response), in percent of the reference or control that the assay uses: 91%
Estimate against measurement, compound 4: 61 percentage points below, outside the stated range (above it).
By their numbers in this assay, from the lowest: compound 2; then compound 1; then compound 3; then compound 4.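

In this assay, going by these compounds alone, replacing the 3,4-dichlorobenzyl arm with 3-azido-2-hydroxypropyl gives a number 36 percentage points higher from compound 3 to compound 4 (beyond the scatter) and so sets the first one-place comparison at this position. It shows that a 3,4-dichlorophenyl ring on the saturated chain carbon bound to an aromatic nitrogen is not required for a large maximal response, since an arm with no ring reaches a higher value here. No measurement among these compounds accounts for the rise.

The azido and hydroxyl groups enter together, so the compounds shown leave open how much of the change belongs to each. A 2-hydroxypropyl arm, a 3-aminopropyl arm or a plain propyl chain in the same place would begin to separate their contributions.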